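The source may report more compounds than this note shows. Statements on the series, on what has been measured and on what is new or still open speak of the compounds shown alone.

Within the data shown here, in a functional assay on HCT-116 cells (Homo sapiens) for inhibition, read by MTT assay, with a stated time of 72 h (a lower number here means a stronger inhibitor, a higher number a weaker inhibitor), compound 1 `COc1cc2c(Oc3ccc(NC(=O)c4nn(-c5ccccc5C)cc(C)c4=O)cc3)ccnc2cc1OCC(=O)NO` gives 9260 nM, the higher of the two numbers so far. Compound 2 `COc1cc2c(Oc3ccc(NC(=O)c4nn(-c5ccccc5C)cc(C)c4=O)cc3F)ccnc2cc1OCCCC(=O)NO` gives 2040 nM, a lower number, and the gap lies beyond the scatter. No change in a single place connects these two compounds, so the gap cannot be assigned to one part of the structure.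

Next is compound 3 `COc1cc2c(Oc3ccc(NC(=O)c4nn(-c5ccccc5C)cc(C)c4=O)cc3)ccnc2cc1OCCCCCCC(=O)NO`, which keeps the core of compound 1 and differs in one place: 5-(hydroxycarbamoyl)pentyl in place of hydroxycarbamoyl on a saturated chain carbon bound to an oxygen on an aromatic ring. Here 5-(hydroxycarbamoyl)pentyl stands in place of hydroxycarbamoyl on a saturated chain carbon bound to an oxygen on an aromatic ring.

Among the measured compounds shown here, no measured step calibrates this change in this assay. A lower number is expected, by a margin beyond the scatter, with compound 2 at 2040 nM as the only weak pointer. The expected size is a 15-fold lower number from compound 1 to compound 3 (1.19 log units; beyond the scatter). For compound 3 the estimated value is 600 nM, with an expected range of 120 nM to 2500 nM.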

Compound 3, half-maximal inhibitory concentration: 660 nM
The estimate for compound 3 lay 1.1-fold (0.04 log units) below the measured number; the measured number falls inside the stated range.
By their numbers in this assay, from the lowest: compound 3; then compound 2; then compound 1.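

In this assay, the step to 5-(hydroxycarbamoyl)pentyl in place of hydroxycarbamoyl on a saturated chain carbon bound to an oxygen on an aromatic ring gives a 14-fold lower number from compound 1 to compound 3 (1.15 log units; beyond the scatter) and lies beyond the scatter. Among these compounds, this is the first change confined to one place, and it shows that this position alone can shift the number by a large margin, which the gap between compound 1 and compound 2 could not show. No measurement shown here gives a cause for this step.

Among the compounds shown here, only two lengths of this chain can be compared directly, so it remains open whether a longer chain or an intermediate one would give a lower number. Also open, as far as these compounds go, is whether a carboxylic acid or an amine could stand in place of the terminal hydroxycarbamoyl on the same chain.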